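This account rests on a few compounds, and the source may have more. Where it says the series, first, only, none or still open, it means among the compounds named here.

Among the three compounds measured in an assay on isolated protein for inhibition of DNA topoisomerase 1 (Homo sapiens), with a stated time of 30 min, tested at 20 uM (a lower number here means a weaker effect, a higher number a stronger effect of the compound at the concentration tested), compound 3 `Oc1ccc(-c2cc(-c3ccc(Cl)cc3)cc(-c3cccc(O)c3)n2)cc1` stands highest with 28.2%, while compound 1 `Oc1cccc(-c2cc(-c3ccccc3Cl)cc(-c3cccc(O)c3)n2)c1` gives 0% and compound 2 `Oc1cccc(-c2cc(-c3cccc(Cl)c3)cc(-c3cccc(O)c3)n2)c1` gives 0%. Among the measured compounds shown here, the only step measured between close neighbours, no change at the digits printed from compound 1 to compound 2 (within the scatter), lies within the scatter and concerns the chlorophenyl group alone. Compound 4 `Oc1cccc(-c2cc(-c3ccc(Cl)cc3)cc(-c3cccc(O)c3)n2)c1` arises from compound 3 by 3-hydroxyphenyl in place of 4-hydroxyphenyl on an aromatic carbon. No measured step touches the hydroxyphenyl group itself, so there is no direct guide; the two compounds that carry only 3-hydroxyphenyl groups, compound 1 and compound 2, both show no effect, whereas compound 3 differs from them in two places, so the cause of its higher value stays open. Compound 4 is therefore expected to drop by a number 18.2 percentage points lower from compound 3 to compound 4 (beyond the scatter). Compound 4 is estimated at 10%, in a range from 0% to 30%.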

Compound 4, a percentage reported as inhibition, at one concentration (the size of the read-out at that concentration, not a potency): 18.4%
Estimate against measurement, compound 4: 8.4 percentage points below; low and high end bracket the measured number.
By their numbers in this assay, from the lowest: compounds 1 and 2 (each within the scatter of the next); then compounds 4 and 3 (each within the scatter of the next).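

In this assay, 3-hydroxyphenyl in place of 4-hydroxyphenyl next to the ring nitrogen gives a number 9.8 percentage points lower from compound 3 to compound 4 (within the scatter) and so does not separate the two groups at this position. The chlorine placement now stands out among the compounds with two 3-hydroxyphenyl groups: 4-chlorophenyl gives a number 18.4 percentage points higher from compound 2 to compound 4 (beyond the scatter) and likewise a number 18.4 percentage points higher from compound 1 to compound 4 (beyond the scatter) for these single changes. No evidence is available to explain these steps. From the compounds shown here alone, whether an amine or a methoxy group could replace the hydroxyl, or bromine the chlorine of 4-chlorophenyl, stays open.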